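Benzyloxy for bromo in a bis-chalcone phenol series

This account rests on a few compounds, and the source may have more. Where it says the series, first, only, none or still open, it means among the compounds named here.

The measured compounds:
compound 1 `Cc1cc(O)c(C(=O)/C=C/c2ccccc2)c(-c2ccc(Br)cc2)c1C(=O)/C=C/c1ccccc1` — 10000 nM
compound 2 `Cc1cc(O)c(C(=O)/C=C/c2ccc(F)cc2)c(-c2ccccc2)c1C(=O)/C=C/c1ccc(F)cc1` — 20000 nM
compound 3 `COc1ccc(/C=C/C(=O)c2c(C)cc(O)c(C(=O)/C=C/c3ccc(OC)cc3)c2-c2ccc(Br)cc2)cc1` — "not active" (no number reported)

In a functional assay on MCF7 cells (Homo sapiens) for cytotoxicity, read by MTT assay, with a stated time of 24 h (a higher number here means a weaker inhibitor, a lower number a stronger inhibitor), compound 1 gives 10000 nM, the lower of the two numbers recorded. Compound 2 gives 20000 nM in this assay, and the two values lie within the scatter of each other, so no order between compound 1 and compound 2 can be read from them. Compound 3 was reported in this assay as "not active" (no number reported), with no number given.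

The step under consideration leads from compound 1 to compound 4 `Cc1cc(O)c(C(=O)/C=C/c2ccccc2)c(-c2ccc(OCc3ccccc3)cc2)c1C(=O)/C=C/c1ccccc1`. The two differ in one place: benzyloxy in place of bromo on an aromatic carbon. Among the compounds with values here, no pair of measured compounds differing in a single place is available, so the size of this step has no precedent here. Since the measured values sit in a narrow, weak range, compound 4 is expected to fall near compound 1, with a step of a 1.2-fold higher number from compound 1 to compound 4 (0.08 log units; within the scatter) that is not expected to exceed the scatter. Compound 4 is estimated at 12000 nM, between 4000 nM and 40000 nM.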

Compound 4, half-maximal inhibitory concentration: "not active" (no number reported)
Compound 4 has no reported number here, so the estimate cannot be set against anything.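

Within the data shown here, compound 4, like compound 3, was reported as "not active" without a number in this assay, so no step from compound 1 to compound 4 can be read. The compounds shown leave open how benzyloxy in place of bromo changes cytotoxicity. No supporting evidence bears on this result.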